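From an aminophenyl ketone to a dichlorophenyl ketone

A few compounds are considered here, and "the series" means these few. Any claim that something is new, unique, unknown or untested is made for them only; others in the source may bear on it.

Compound 1 `COc1cc(-c2cc(/C=C/C(=O)c3ccc(N)cc3)[nH]n2)cc(OC)c1OC`: 3750 nM
Compound 2 `COc1ccc(-c2cc(/C=C/C(=O)c3ccc(OC)c(OC)c3)[nH]n2)cc1`: 4090 nM

Of the compounds shown here, two have been measured in a functional assay on OVCAR-5 cells (Homo sapiens) for inhibition, read by sulforhodamine B assay, with a stated time of 48 h; a lower number here means a stronger inhibitor of growth, a higher number a weaker inhibitor of growth. Compound 1 gives 3750 nM, and compound 2 gives 4090 nM. Their values lie within the scatter of each other, so neither can be called the stronger inhibitor on these numbers; compound 1 simply sits alongside compound 2.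

The next compound, compound 3 `COc1cc(-c2cc(/C=C/C(=O)c3ccc(Cl)c(Cl)c3)[nH]n2)cc(OC)c1OC`, keeps the core of compound 1 and changes only the aryl ketone: 3,4-dichlorophenyl in place of 4-aminophenyl on a carbonyl carbon. Among the compounds with values here, no pair of measured compounds differs in one place, so there is no measured step to lean on, and the two values in this assay give no indication of how the carbonyl-bound aryl group moves the number.

The step from compound 1 to compound 3 is therefore expected to be small, with no direction favoured beyond the scatter, as expressed by a 1.3-fold lower number from compound 1 to compound 3 (0.10 log units; within the scatter). For compound 3 the estimate in this assay is 3000 nM, with a range from 900 nM to 10000 nM.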

Compound 3, concentration for total growth inhibition: > 100000 nM
Compound 3: only a limit was reported (the forecaster's own chance of this, stated with the estimate: 5%); at least 33-fold (1.52 log units) between middle value and limit.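

Within the data shown here, on the core of compound 1, the aryl group on a carbonyl carbon turns out to matter: in this assay, 3,4-dichlorophenyl in place of 4-aminophenyl gives an at least 26-fold higher number from compound 1 to compound 3 (1.42 log units; beyond the scatter), a step beyond the scatter and the first comparison here in which only this group differs. Among these compounds, until now, the only pair available, compound 1 and compound 2, differed in more than one place and could say nothing about this group alone. The reading for compound 3, > 100000 nM, is a limit of the assay and not a number, so the step fixes a direction and a minimum size rather than an exact distance: the limit of > 100000 nM in this assay, at which 1 of the 3 values shown sits.

As far as these compounds go, the exchange swaps the whole substituted ring at once, so it remains open whether the step follows the loss of the amine or the arrival of the two chlorines; a plain phenyl or a hydroxyphenyl on the same carbonyl carbon would help separate the two. From the compounds shown here alone, it also remains open whether the same exchange would give a similar step on the core of compound 2.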